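Notes on cyano in place of ethoxycarbonyl

A few compounds are considered here, and "the series" means these few. Any claim that something is new, unique, unknown or untested is made for them only; others in the source may bear on it.

- compound 1 `N#CCC(=O)Nc1sc(C(=O)Nc2ccc(Cl)cc2)c(-c2ccccc2)c1C#N` gives 1400 nM
- compound 2 `N#Cc1c(N)sc(C(=O)Nc2ccccc2)c1-c1ccccc1` gives 8280 nM
- compound 3 `CCOC(=O)c1c(NC(=O)CC#N)sc(C(=O)Nc2ccccc2)c1-c1ccccc1` gives 320 nM

All three values come from a functional assay on A549 cells (Homo sapiens) for inhibition, read by MTT assay; on this read-out higher numbers stand for weaker inhibition and lower numbers for stronger inhibition. Compound 3 has the lowest number of the set, and the gaps to compound 1 and compound 2 both lie beyond the usual scatter. Compound 4 `N#CCC(=O)Nc1sc(C(=O)Nc2ccccc2)c(-c2ccccc2)c1C#N` has not been measured. It departs from compound 3 by cyano in place of ethoxycarbonyl on an aromatic carbon, which is cyano in place of ethoxycarbonyl on an aromatic carbon.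

Going by the values given here, no measured pair isolates this change, so the evidence is indirect. Compound 1 also carries cyano at that place and gives 1400 nM. Compound 2 carries it too and gives 8280 nM. Both numbers are higher than that of compound 3, though both compounds also differ from it elsewhere.

In this assay a step to a higher number, beyond the scatter, is expected: a 3.4-fold higher number from compound 3 to compound 4 (0.54 log units; beyond the scatter). Compound 4 is estimated at 1100 nM, with an expected range of 350 nM to 3500 nM.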

Compound 4, half-maximal inhibitory concentration: 7590 nM
The estimate for compound 4 lay 6.9-fold (0.84 log units) below the measured number; the whole stated range lies below it.
By their numbers in this assay, from the lowest: compound 3; then compound 1; then compounds 4 and 2 (each within the scatter of the next).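

The direct pair now prices this change on the aromatic carbon: in this assay cyano in place of ethoxycarbonyl gives a 24-fold higher number from compound 3 to compound 4 (1.38 log units; beyond the scatter) and is a large step. With cyano held at that place, (cyanomethyl)carbonyl in place of hydrogen on the nitrogen gives a 1.1-fold lower number from compound 2 to compound 4 (0.04 log units; within the scatter) and leaves the two compounds within the scatter of each other. The chloro on compound 1 also counts, since hydrogen in place of chloro gives a 5.4-fold higher number from compound 1 to compound 4 (0.73 log units; beyond the scatter) and is a modest step.

Nothing here accounts for the size of the ethoxycarbonyl step. Open, as far as these compounds go, are a carboxylic acid, a primary amide or a longer ester chain on this aromatic carbon, and whether ethoxycarbonyl and chloro together shift the number further.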